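The source may hold more compounds than are shown below. What is called first, only, known or untested is meant among the compounds shown, and "the series" means these compounds.

Working notes on the series. All three measured compounds share one core and differ only in the group on a saturated chain carbon, two bonds along the chain from an aromatic nitrogen. Compound 1 `CCCn1c(=O)n(CCC(N)=O)c(=O)c2[nH]cnc21` gives 31500 nM in an assay on Cerebral cortex for binding affinity to adenosine receptor A1 (Cavia porcellus), read by radioligand binding; a lower number here means a stronger inhibitor, a higher number a weaker inhibitor. Compound 2 `CCCn1c(=O)n(CCC#N)c(=O)c2[nH]cnc21` gives 15900 nM in this assay, and compound 3 `CCCn1c(=O)n(CCCN(C)C)c(=O)c2[nH]cnc21` gives 43200 nM in this assay. Compound 3 stands at the high end of the three numbers: the step of a 1.4-fold higher number from compound 1 to compound 3 (0.14 log units; within the scatter) is within the scatter, while the step of a 2.7-fold higher number from compound 2 to compound 3 (0.43 log units; beyond the scatter) is beyond it, though modest. Compound 4 `CCCn1c(=O)n(CCO)c(=O)c2[nH]cnc21` carries hydroxy in place of (dimethylamino)methyl on a saturated chain carbon, two bonds along the chain from an aromatic nitrogen. Among the measured compounds shown here, no measured step introduces a hydroxy group; the steps that bear on the same chain position, a 1.4-fold higher number from compound 1 to compound 3 (0.14 log units; within the scatter) and a 2.7-fold higher number from compound 2 to compound 3 (0.43 log units; beyond the scatter), each swapped one terminal group for another and moved the number by little. A step of similar size is therefore expected here, if anything toward a lower number, and the expected step is a 1.7-fold lower number from compound 3 to compound 4 (0.24 log units; within the scatter). Compound 4 is estimated at 25000 nM, with a range from 8000 nM to 80000 nM.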

Compound 4, inhibition constant: 50000 nM
For compound 4 the middle estimate is 2.0-fold (0.30 log units) below the measured one; the range from low to high includes it.
By their numbers in this assay, from the lowest: compounds 2, 1, 3 and 4 (each within the scatter of the next, the first and the last beyond it).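

In this assay, hydroxy at this position cannot be told apart from the two other non-nitrile end groups: a 1.2-fold higher number from compound 3 to compound 4 (0.06 log units; within the scatter) and a 1.6-fold higher number from compound 1 to compound 4 (0.20 log units; within the scatter). Only the comparison with the nitrile separates, giving a 3.1-fold higher number from compound 2 to compound 4 (0.50 log units; beyond the scatter), so compound 2 and compound 4 mark the two ends of the series, and even that step is modest. The change from (dimethylamino)methyl to hydroxy, and the same swap read as 3-(dimethylamino)propyl to 2-hydroxyethyl, thus leaves the number within the scatter, and no supporting data on hand account for this result.

The compounds shown leave open whether a carboxylic acid, a primary amine or a longer chain on this saturated chain carbon would move the number further from the four values seen so far. From the compounds shown here alone, a phenyl group at the same place is equally open, as none of the four end groups carries a ring.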